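This account rests on a few compounds, and the source may have more. Where it says the series, first, only, none or still open, it means among the compounds named here.

Measured so far in a physicochemical assay for solubility, at pH 6.8; a higher number here means a more soluble compound, a lower number a less soluble compound:
- compound 1 `CNCc1cc(Oc2ccc3c(ccn3C(=O)Nc3cccc(C(F)(F)F)c3)c2)ncn1`: 64000 nM
- compound 2 `Cc1cncc(NC(=O)n2ccc3cc(Oc4ncnc5c4CCNC5)ccc32)c1`: 190000 nM
- compound 3 `CC(C)c1cc(NC(=O)n2ccc3cc(Oc4ncnc5c4CCNC5)ccc32)n[nH]1`: 833000 nM

Compound 2 holds the middle place among these three numbers, with compound 1 lower and compound 3 higher, and both gaps go beyond the usual scatter of repeated measurements.

The next compound, not yet measured, is compound 4 `CC1(c2cc(NC(=O)n3ccc4cc(Oc5ncnc6c5CCNC6)ccc43)n[nH]2)CC1`. It keeps the core of compound 2 and changes one group: 5-(1-methylcyclopropyl)-1H-pyrazol-3-yl in place of 5-methylpyridin-3-yl on an amide-type nitrogen. In words, 5-(1-methylcyclopropyl)-1H-pyrazol-3-yl takes the place of 5-methylpyridin-3-yl on an amide-type nitrogen.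

Among the measured compounds shown here, one measured step bears directly on this change: a 4.4-fold higher number from compound 2 to compound 3 (0.64 log units; beyond the scatter). It is a modest step, and it removes the same 5-methylpyridin-3-yl, with 5-isopropyl-1H-pyrazol-3-yl entering instead. The group entering in compound 4 differs from that one only in carrying 1-methylcyclopropyl where compound 3 carries isopropyl. For the measured compounds named here, no measured pair shows what that last swap does, so a single step is the whole guide here. A rise in the same direction is therefore expected, of similar or slightly smaller size. The expected change is a 3.4-fold higher number from compound 2 to compound 4 (0.53 log units; beyond the scatter). For compound 4 the estimated value is 650000 nM, with an expected range from 280000 nM to 1400000 nM.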

Compound 4, solubility: 252000 nM
For compound 4 the middle estimate is 2.6-fold (0.41 log units) above the measured one; the whole stated range lies above it.
By their numbers in this assay, from the lowest: compound 1; then compounds 2 and 4 (each within the scatter of the next); then compound 3.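

Read in this assay, placing 5-(1-methylcyclopropyl)-1H-pyrazol-3-yl on the amide-type nitrogen in place of 5-methylpyridin-3-yl gives a 1.3-fold higher number from compound 2 to compound 4 (0.12 log units; within the scatter), so this exchange does not clearly separate the two compounds. The rise seen with 5-isopropyl-1H-pyrazol-3-yl therefore does not carry over to every group of this kind: 1-methylcyclopropyl in place of isopropyl on an aromatic carbon gives a 3.3-fold lower number from compound 3 to compound 4 (0.52 log units; beyond the scatter), showing that in these compounds the outcome depends on that small group as well as on the five-membered aromatic ring that carries it. Nothing in the data shown accounts for the size of this step.

With only isopropyl and 1-methylcyclopropyl shown on that aromatic carbon, it remains open whether a plain methyl, a tert-butyl or a hydroxymethyl group would give a number closer to that of compound 3 or that of compound 4. From the compounds shown here alone, it is also open whether the exchange of isopropyl for 1-methylcyclopropyl would give a similar step on a different core, such as that of compound 1.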